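Phenyl replaces hexyl at the chain end of compound 3

The compounds below may be only part of what the source reports. "The series", "measured", "known", "first", "only" and "open" are said of these compounds alone.

In a functional assay on MIA PaCa-2 cells (Homo sapiens) for antiproliferative activity, read by MTT assay, with a stated time of 3 days (a lower number here means a stronger inhibitor, a higher number a weaker inhibitor), compound 3 (`CCCCCCCCC#Cc1cn(C/C=C/CN2C(=O)c3ccccc3C2=O)c(=O)[nH]c1=O`) gives > 100000 nM, which is a limit of the assay and not a number. Compound 2 (`O=C1c2ccccc2C(=O)N1C/C=C\Cn1cc(C#Cc2ccc(Br)cc2)c(=O)[nH]c1=O`) gives > 100000 nM, which is also a limit. Compound 1 (`CCCCCCCCC#Cc1cn(C/C=C\CN2C(=O)c3ccccc3C2=O)c(=O)[nH]c1=O`) gives a measured number, 68000 nM. Compound 3 therefore sits at the limit of > 100000 nM in this assay, at which 2 of the 3 values shown sit.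

Compound 4 (`O=C1c2ccccc2C(=O)N1C/C=C/Cn1cc(C#CCCc2ccccc2)c(=O)[nH]c1=O`) carries phenyl in place of hexyl on a saturated chain carbon, two bonds along the chain from a triple-bonded carbon.

For the measured compounds named here, two measured steps bear on this change. The step of an at least 1.4-fold higher number from compound 1 to compound 2 (0.16 log units; that floor lies within the scatter) puts 4-bromophenyl in place of octyl, so a ring replaces a chain there too. The step of an at least 1.4-fold higher number from compound 1 to compound 3 (0.16 log units; that floor lies within the scatter) touches only the configuration, as shown by the fact that compounds 1 and 3 differ only in the configuration as drawn. Both are floors that lie within the scatter, so no step beyond the scatter is expected in this assay, and no direction can be named.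

The expected change is a number no higher from compound 3 to compound 4 (the limit leaves the size open), an estimate within the scatter. Compound 4 is expected to give about 100000 nM. Its estimated range runs from 50000 nM to 160000 nM.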

Compound 4, half-maximal inhibitory concentration: 27000 nM
For compound 4 the middle estimate is 3.7-fold (0.57 log units) above the measured one; measured number outside the range, below it.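

In this assay, the group at the chain end makes a readable difference (an at least 3.7-fold lower number from compound 3 to compound 4 (0.56 log units; beyond the scatter)), and this is the first step among these compounds to lie beyond the scatter. The earlier steps shown here gave only floors within the scatter and could name no direction, whereas this one links phenyl in place of hexyl, on a saturated chain carbon, two bonds along the chain from a triple-bonded carbon, to a lower number. On these data alone, compound 3 gives > 100000 nM as a limit and not a number, so the full size of the step stays unknown: the limit of > 100000 nM in this assay, at which 2 of the 4 values shown sit.

As far as these compounds go, it remains open whether the aromatic ring itself matters, which a cyclohexyl group in the same place could test. A carboxylic acid or an amine on the phenyl ring is also untested here, as is phenyl paired with the double bond drawn Z.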